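This account rests on a few compounds, and the source may have more. Where it says the series, first, only, none or still open, it means among the compounds named here.

Compound 1 `CCN1CCN(c2ccc3c(c2)oc(=O)n3C(=O)NCCCCc2ccccc2)CC1` was run through an ADME assay on microsomes from liver (Mus musculus) for metabolic stability, read by LC-MS, using NADPH, with stated times of 15 min and 60 min, tested at 4.6 uM; on this read-out lower numbers stand for a shorter-lived compound and higher numbers for a longer-lived compound. In this assay compound 1 gives < 0.0834 h, which is a limit of the assay rather than a number. A second compound, compound 2 `O=C(NCCCCc1ccccc1)n1c2c(oc1=O)CCNC2`, went through the same test. In this assay compound 2 gives < 0.25 h, again only a limit and not a number. For the measured compounds named here, compound 1 therefore stands at the limit of < 0.0834 h in this assay, at which 1 of the 2 values shown sits, and the one other value sits at the limit of < 0.25 h in this assay, at which 1 of the 2 values shown sits. The next compound, compound 3 `CN1CCC(c2ccc3c(c2)oc(=O)n3C(=O)NCCCCc2ccccc2)CC1`, differs from compound 1 by 1-methylpiperidin-4-yl in place of 4-ethylpiperazin-1-yl on an aromatic carbon. Going by the values given here, no step between measured compounds is known here; the change an at least 1.1-fold higher number from compound 1 to compound 3 (0.07 log units; that floor lies within the scatter) is expected to stay within the usual scatter. Compound 3 is estimated to give 0.1 h, somewhere between 0.04 h and 0.3 h.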

Compound 3, half-life: 0.667 h
Beside the measured number, compound 3's estimate is 6.7-fold (0.82 log units) below it; measured number outside the range, above it.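

In this assay, placing 1-methylpiperidin-4-yl in place of 4-ethylpiperazin-1-yl on an aromatic carbon gives an at least 7.9-fold higher number from compound 1 to compound 3 (0.90 log units; beyond the scatter), so a change at this position can move the half-life beyond the scatter. Compound 3 is also the first compound shown with a number rather than a limit. The size of the step is only a floor, since it starts from a limit for compound 1: the limit of < 0.0834 h in this assay, at which 1 of the 3 values shown sits.

This change swaps a ring nitrogen for carbon and ethyl for methyl at once, and the compounds shown cannot separate the two. A 4-methylpiperazin-1-yl group at this position would help to tell them apart.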